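The source may hold more compounds than are shown below. What is called first, only, known or untested is meant among the compounds shown, and "the series" means these compounds.

Measured so far in a functional assay on MCF7 cells (Homo sapiens) for antiproliferative activity, read by MTT assay, with a stated time of 48 h; a higher number here means a weaker inhibitor, a lower number a stronger inhibitor:
- compound 1 `COc1ccc(C2=N/C(=C\c3cc(Br)cc(Br)c3OC(C)=O)C(=O)NN2C(N)=S)cc1OC` gives 13400 nM
- compound 2 `CC(=O)Oc1c(Br)cc(Br)cc1/C=C1\N=C(c2ccccc2)N(c2ncc(-c3ccccc3)s2)NC1=O` gives 38300 nM

Of these two numbers, compound 2 holds the higher (38300 nM), which means the weaker inhibition, and its gap to compound 1 lies beyond the scatter. Next to be read is compound 3 `COc1ccc(C2=N/C(=C\c3cc(Br)cc(Br)c3OC(C)=O)C(=O)NN2c2ncc(-c3ccccc3)s2)cc1OC`, which keeps the 5-phenyl-1,3-thiazol-2-yl group of compound 2 and carries 3,4-dimethoxyphenyl in place of phenyl on a carbon with a double bond to nitrogen. Within the data shown here, no measured pair isolates this change, so its size in this assay has to be judged indirectly. Among the measured compounds shown here, the only guide is compound 1, which carries the 3,4-dimethoxyphenyl group and reads lower (13400 nM), but it also lacks the 5-phenyl-1,3-thiazol-2-yl group, so only part of that gap can be expected to carry over. The expected step is small and downward (a 1.6-fold lower number from compound 2 to compound 3 (0.20 log units; within the scatter)) and would stay within the scatter. For compound 3 the estimated value is 24000 nM with an expected range from 9000 nM to 60000 nM in this series.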

Compound 3, half-maximal inhibitory concentration: 4330 nM
Compound 3: the middle estimate sits 5.5-fold (0.74 log units) above what was measured; the whole stated range lies above it.
By their numbers in this assay, from the lowest: compound 3; then compound 1; then compound 2.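

In this assay, among these compounds, the step at the carbon with a double bond to nitrogen, 3,4-dimethoxyphenyl in place of phenyl with the 5-phenyl-1,3-thiazol-2-yl group held fixed, is an 8.8-fold lower number from compound 2 to compound 3 (0.95 log units; beyond the scatter), which gives the first direct reading of this position and shows that the change there registers beyond the scatter. With 3,4-dimethoxyphenyl held fixed, the change on the amine nitrogen in a ring also registers, as the group of 11 heavy atoms in place of the group of 3 heavy atoms gives a 3.1-fold lower number from compound 1 to compound 3 (0.49 log units; beyond the scatter), and compound 3, which carries both 3,4-dimethoxyphenyl and 5-phenyl-1,3-thiazol-2-yl, has the lowest number of the series. No measurement at hand accounts for either step.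

From the compounds shown here alone, the step at this position is read only with 5-phenyl-1,3-thiazol-2-yl in place, so its size alongside the group of 3 heavy atoms remains open. Going by these compounds, it also remains open whether both methoxy groups contribute, or whether a single methoxy group, a hydroxyl or an amine on that phenyl would give a similar number.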